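The compounds below may be only part of what the source reports. "The series", "measured", "known", "first", "only" and "open" are said of these compounds alone.

Measured compounds:
compound 1 `O=C(Cn1cc(CN2C(=O)C(=O)c3c(Cl)ccc(Cl)c32)nn1)OC1CCCCC1` — in a functional assay on MCF7 cells (Homo sapiens) for inhibition, read by CCK-8 assay, with a stated time of 72 h (on this read-out higher numbers stand for weaker inhibition and lower numbers for stronger inhibition), compound 1 gives 18900 nM
compound 2 `O=C1C(=O)N(Cc2cn(CC(=O)N3CCOCC3)nn2)c2c(Cl)ccc(Cl)c21` — in this assay compound 2 gives 146000 nM
compound 3 `O=C1C(=O)N(Cc2cn(CC(=O)N3CCNCC3)nn2)c2c(Cl)ccc(Cl)c21` — in this assay compound 3 gives "nd(insoluble)" (no result reported), so no number was reported for it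

Among the measured compounds shown here, compound 1 stands at the lowest of the two numbers; the one measured step that leaves it is a 7.7-fold higher number from compound 1 to compound 2 (0.89 log units; beyond the scatter), where morpholin-4-yl replaces cyclohexyloxy on a carbonyl carbon. Compound 3 adds nothing, as it gave no number.

Compound 4 `O=C(Cn1cc(CN2C(=O)C(=O)c3c(Cl)ccc(Cl)c32)nn1)Nc1ccccc1` differs from compound 1 by anilino in place of cyclohexyloxy on a carbonyl carbon. For the measured compounds named here, the only step that bears on this is the one to compound 2, which also swaps the cyclohexyloxy group on the same carbonyl carbon and gave a modest rise beyond the scatter. Anilino is a different replacement from morpholin-4-yl, so the evidence is thin, but the one precedent points toward a higher number rather than a lower one. Compound 4 is therefore expected to show a small step of a 1.6-fold higher number from compound 1 to compound 4 (0.20 log units; within the scatter), likely within or just beyond the scatter. The estimate for compound 4 in this assay is 30000 nM, with a range from 8000 nM to 120000 nM.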

Compound 4, half-maximal inhibitory concentration: 38500 nM
Beside the measured number, compound 4's estimate is 1.3-fold (0.11 log units) below it; measured number inside the range.
By their numbers in this assay, from the lowest: compound 1; then compound 4; then compound 2.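

In this assay, anilino is a second replacement for cyclohexyloxy on this carbonyl carbon, and it also raises the number, a 2.0-fold higher number from compound 1 to compound 4 (0.31 log units; beyond the scatter), though by a smaller step than morpholin-4-yl. The two replacements are also separated from each other, a 3.8-fold lower number from compound 2 to compound 4 (0.58 log units; beyond the scatter), so the size of the rise depends on which group enters and not only on the loss of cyclohexyloxy. Nothing available explains this order among the three groups.

Anilino changes both the ring and the atom linking it to the carbonyl carbon, so it remains open whether cyclohexylamino or phenoxy would read closer to compound 1 or to compound 4. Also open, as far as these compounds go, is how a small group such as methoxy would read on this carbonyl carbon.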